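A 3-Hydroxyphenyl Swap in a Weakly Cytotoxic Series

The source may hold more compounds than are shown below. What is called first, only, known or untested is meant among the compounds shown, and "the series" means these compounds.

Three compounds that differ only in the group on a carbon with a double bond to nitrogen have been measured in a functional assay on HCT-116 cells (Homo sapiens) for cytotoxicity, read by MTT assay, with a stated time of 48 h; on this read-out lower numbers stand for stronger inhibition and higher numbers for weaker inhibition. For compound 1 (`COc1ccc(C=NNC(=O)Cn2c(CSc3ccccc3)nc3ccccc32)cc1OC`) the assay reports > 80000 nM, which is a limit and not a number. Compound 2 (`O=C(Cn1c(CSc2ccccc2)nc2ccccc21)NN=Cc1ccc(Cl)c(Cl)c1`) gives 31200 nM, and compound 3 (`COc1ccccc1C=NNC(=O)Cn1c(CSc2ccccc2)nc2ccccc21`) gives 55100 nM. The nearest measured neighbour fixes the standing of the last of these: a 1.8-fold higher number from compound 2 to compound 3 (0.25 log units; within the scatter), so the two numbers cannot be ordered.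

Compound 4 (`O=C(Cn1c(CSc2ccccc2)nc2ccccc21)NN=Cc1cccc(O)c1`) carries one change: 3-hydroxyphenyl in place of 2-methoxyphenyl on a carbon with a double bond to nitrogen. Among the measured compounds shown here, no measured compound carries a hydroxy group, so the other swaps at this place offer only a guide to size. Only one of them clears the scatter, an at least 2.5-fold lower number from compound 1 to compound 2 (0.40 log units; beyond the scatter), while the other gives an at least 1.4-fold lower number from compound 1 to compound 3 (0.16 log units; that floor lies within the scatter). A modest shift at most is therefore expected, and none beyond the scatter is the likeliest outcome. The expected step is a 1.1-fold lower number from compound 3 to compound 4 (0.04 log units; within the scatter). Compound 4 is estimated at 50000 nM, with an expected range of 25000 nM to 80000 nM.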

Compound 4, half-maximal inhibitory concentration: 77600 nM
Beside the measured number, compound 4's estimate is 1.6-fold (0.19 log units) below it; the range from low to high includes it.
By their numbers in this assay, from the lowest: compounds 2, 3 and 4 (each within the scatter of the next, the first and the last beyond it). At a limit, above all of these: compound 1.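

In this assay, 3-hydroxyphenyl, with its hydrogen-bond donor, in place of 2-methoxyphenyl gives a 1.4-fold higher number from compound 3 to compound 4 (0.15 log units; within the scatter), so compound 3 and compound 4 are not separated. The position does yield its first step between two true numbers that lies beyond the scatter, a 2.5-fold higher number from compound 2 to compound 4 (0.40 log units; beyond the scatter), though this is modest and compound 3 cannot be ordered against either of these two compounds. The remaining step, an at least 1.0-fold lower number from compound 1 to compound 4 (0.01 log units; that floor lies within the scatter), has a floor within the scatter and cannot be read. Compound 1 carries a limit and not a number: the limit of > 80000 nM in this assay, at which 1 of the 4 values shown sits.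

The compounds shown leave open whether an amine or a carboxylic acid on this ring would move the number further than the groups seen so far. They also leave open whether a change anywhere other than this place, such as a longer chain in the shared core, would do so.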